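Swapping the amide aryl group for pyridin-2-yl

The source may hold more compounds than are shown below. What is called first, only, known or untested is meant among the compounds shown, and "the series" means these compounds.

Among the compounds with values here, all three compounds measured so far share the same core, differing only in the aryl group joined to the carbonyl carbon of the amide. Compound 1 `O=C(Nc1ccc(Cl)c(-c2nnc3c(Cl)cccn23)c1)c1ccccc1` carries a plain phenyl there, and in a functional assay on U-251 cells (Homo sapiens) for antiproliferative activity, read by MTT assay, with a stated time of 72 h (on this read-out higher numbers stand for weaker inhibition and lower numbers for stronger inhibition), compound 1 gives 73500 nM. Compound 2 `O=C(Nc1ccc(Cl)c(-c2nnc3c(Cl)cccn23)c1)c1ccccc1Cl` adds a chloro on that ring. In this assay compound 2 reaches only the limit of the assay, > 100000 nM, not a number. Compound 3 `Cc1cc(Cl)ccc1C(=O)Nc1ccc(Cl)c(-c2nnc3c(Cl)cccn23)c1` carries a 4-chloro-2-methylphenyl in place of phenyl. Compound 3 likewise gives only the limit > 100000 nM in this assay, so it stands at the weak end of the set, with 2 of the 3 values at that same limit (the limit of > 100000 nM in this assay, at which 2 of the 3 values shown sit).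

Compound 4 `O=C(Nc1ccc(Cl)c(-c2nnc3c(Cl)cccn23)c1)c1ccccn1` is the next member: pyridin-2-yl in place of 4-chloro-2-methylphenyl on a carbonyl carbon. The measured steps that touch this position are modest or unreadable: an at least 1.3-fold higher number from compound 1 to compound 3 (0.13 log units; that floor lies within the scatter), an at least 1.3-fold higher number from compound 1 to compound 2 (0.13 log units; that floor lies within the scatter), and a step that the two limits leave unreadable from compound 2 to compound 3. Every aryl variant so far sits near or at the limit, so the expectation for compound 4 is a number close to that of compound 1, with a real chance of another limit, and the expected step is an at least 1.1-fold lower number from compound 3 to compound 4 (0.04 log units; that floor lies within the scatter). Compound 4 is therefore estimated at 90000 nM, within 25000 nM to 300000 nM.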

Compound 4, half-maximal inhibitory concentration: 79000 nM
Compound 4: middle estimate off by 1.1-fold (0.06 log units), on the high side; the range from low to high includes it.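

The pyridin-2-yl ring, the only ring shown here with a hetero atom, cannot be told apart from plain phenyl on this carbonyl carbon in this assay: a 1.1-fold higher number from compound 1 to compound 4 (0.03 log units; within the scatter). Against the two chlorinated rings, the comparison gives an at least 1.2-fold lower number from compound 3 to compound 4 (0.10 log units; that floor lies within the scatter) and an at least 1.2-fold lower number from compound 2 to compound 4 (0.10 log units; that floor lies within the scatter), so compound 4 yields a measured number, yet neither floor shows a real gain. Compound 2 and compound 3 remain at a limit of the assay rather than a number, so the set still has only two true numbers, and they agree within the scatter: the limit of > 100000 nM in this assay, at which 2 of the 4 values shown sit.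

From the compounds shown here alone, the true values of compound 2 and compound 3 lie beyond the limit, so how much the chloro and methyl groups weaken the effect, if they do at all, stays unknown. Also open, going by these compounds, is whether any group on this carbonyl carbon can bring the number far lower, for example a cyclohexyl ring in place of the aromatic ring, or a phenyl ring carrying an amine or a carboxylic acid.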